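This account rests on a few compounds, and the source may have more. Where it says the series, first, only, none or still open, it means among the compounds named here.

Measured in a toxicity assay on HEK-293T cells (Homo sapiens) for cytotoxicity, read by CCK-8 assay, with a stated time of 48 h; a lower number here means that less compound is tolerated, a higher number that more compound is tolerated:
Compound 1 `Cn1cc(SCc2nnc(SCc3cccc(Cl)c3Cl)n2-c2c(Cl)cccc2Cl)c2ccccc21` gives > 100000 nM, a limit of the assay.
Compound 2 `Cn1cc(SCc2nnc(SCc3cc(Cl)ccc3Cl)n2-c2c(Cl)cccc2Cl)c2ccccc21` gives > 100000 nM, also a limit.
Compound 3 `Cn1cc(SCc2nnc(SCc3c(Cl)cccc3Cl)n2-c2c(Cl)cccc2Cl)c2ccccc21` gives > 100000 nM, again a limit.

Going by the values given here, compound 3 therefore stands at the limit of > 100000 nM in this assay, at which 3 of the 3 values shown sit, so no compound here has a readable number in this assay . The steps a step that the two limits leave unreadable from compound 1 to compound 2, a step that the two limits leave unreadable from compound 1 to compound 3 and a step that the two limits leave unreadable from compound 2 to compound 3 remain without a size for that reason. Compound 4 `Cn1cc(SCc2nnc(SCc3ccc(Cl)cc3C(F)(F)F)n2-c2c(Cl)cccc2Cl)c2ccccc21` differs from compound 3 by 4-chloro-2-(trifluoromethyl)phenyl in place of 2,6-dichlorophenyl on a saturated chain carbon bound to a sulfur. Among the compounds with values here, no measured step gives a readable size for such a change; the three values only show that the shared core tolerated three variants of the group on that saturated chain carbon without reaching a number. The expected step is a step that the limit leaves unreadable from compound 3 to compound 4, with no direction beyond the scatter. Compound 4 is thus estimated at 150000 nM, within 50000 nM to 450000 nM.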

Compound 4, half-maximal cytotoxic concentration: 56500 nM
The estimate for compound 4 lay 2.7-fold (0.42 log units) above the measured number; measured number inside the range.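

In this assay compound 4 is the only compound shown with a readable number, 56500 nM. Placing 4-chloro-2-(trifluoromethyl)phenyl on a saturated chain carbon bound to a sulfur gives an at least 1.7-fold lower number from compound 3 to compound 4 (0.24 log units; that floor lies within the scatter), an at least 1.7-fold lower number from compound 2 to compound 4 (0.24 log units; that floor lies within the scatter) and an at least 1.7-fold lower number from compound 1 to compound 4 (0.24 log units; that floor lies within the scatter), so each floor leaves this change not shown to exceed the scatter. Compounds 1, 2 and 3 each remain at a limit: the limit of > 100000 nM in this assay, at which 3 of the 4 values shown sit.

Whether the trifluoromethyl group or the chlorine of the entering group accounts for the number stays open. Also open, as far as these compounds go, is how an amine or a carboxylic acid in that place would read.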